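Swapping the morpholine urea for a diethyl urea

The compounds below may be only part of what the source reports. "The series", "measured", "known", "first", "only" and "open" are said of these compounds alone.

Compound 1 `CC1(C)N=C(N)N=C(N)N1c1cccc(CNC(=O)Nc2cccc(C#N)c2)c1` gives 8.19 in an assay on isolated protein for inhibition of Dihydrofolate reductase (Mus musculus); on this read-out lower numbers stand for lower potency and higher numbers for higher potency (the scale is a negative logarithm)
Compound 2 `CC1(C)N=C(N)N=C(N)N1c1cccc(CNC(=O)Nc2cccc(Cl)c2)c1` gives 8.05
Compound 3 `CC1(C)N=C(N)N=C(N)N1c1cccc(CNC(=O)N2CCOCC2)c1` gives 6.43

All three share the same core and differ only at the far end of the urea. Compound 3 stands lowest of the three measured compounds: the step of a number 1.76 log units lower from compound 1 to compound 3 (beyond the scatter) and the step of a number 1.62 log units lower from compound 2 to compound 3 (beyond the scatter) both show a large loss when an aromatic amine on the carbonyl carbon is exchanged for morpholin-4-yl, whereas the step of a number 0.14 log units lower from compound 1 to compound 2 (within the scatter) shows no real difference between the two aromatic amines.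

Compound 4 `CCN(CC)C(=O)NCc1cccc(N2C(N)=NC(N)=NC2(C)C)c1` is not yet measured. Its change from compound 3 is diethylamino in place of morpholin-4-yl on a carbonyl carbon. Among the measured compounds shown here, no measured step covers an exchange of one non-aromatic amine for another, so the bearing of the two large steps is only indirect: both non-aromatic ureas sit on the low side of the set. The expected step of a number 0.03 log units lower from compound 3 to compound 4 (within the scatter) is therefore small, in no particular direction. Compound 4 is estimated at 6.4, with a range from 5.8 to 7.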

Compound 4, logarithm of the reciprocal of the active concentration, log(1/C): 6.11
For compound 4 the middle estimate is 0.29 log units above the measured one; low and high end bracket the measured number.
By their numbers in this assay, from the lowest: compound 4; then compound 3; then compounds 2 and 1 (each within the scatter of the next).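

Among the compounds shown here, the step of a number 0.32 log units lower from compound 3 to compound 4 (beyond the scatter) in this assay is the first direct exchange of one non-aromatic amine for another on this carbonyl carbon, and it shows that the position responds to such a swap, though only modestly. The steps of a number 1.94 log units lower from compound 2 to compound 4 (beyond the scatter) and a number 2.08 log units lower from compound 1 to compound 4 (beyond the scatter) are far larger and place compound 4 lowest of the four, so the main divide in this set remains between the two aromatic amines and the two non-aromatic ones. Nothing measured here gives a reason for these differences.

Piperidin-1-yl, the same ring with carbon in place of the oxygen, would show whether the ring or its oxygen separates compound 3 from compound 4. Cyclohexylamino would show whether the high numbers go with the aromatic ring or with the hydrogen kept on that nitrogen.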